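Aryl in place of isopropyl on the urea nitrogen

The source may report more compounds than this note shows. Statements on the series, on what has been measured and on what is new or still open speak of the compounds shown alone.

Working notes on a series of cyclic ureas and one thiourea tested in a functional assay on T98G cells (Homo sapiens) for inhibition, read by MTT assay, with a stated time of 72 h; a lower number here means a stronger inhibitor, a higher number a weaker inhibitor. Compound 1 `COc1cccc(NC(=S)NC2CC(C)(C)Oc3ccc(Br)cc32)c1` gives 87000 nM in this assay. Compound 3 `CC1(C)CC(NC(=O)Nc2ccccc2Cl)c2cc(Br)ccc2O1` gives 11000 nM in this assay. Compound 2 `CC(C)NC(=O)NC1CC(C)(C)Oc2ccc(Cl)cc21` is reported in this assay only as a limit, > 100000 nM, with no number attached; it sits at the limit of > 100000 nM in this assay, at which 1 of the 3 values shown sits. On the numbers shown, compound 2 therefore stands at the weak end of the set, with no measured inhibition inside the tested range, while compound 3 is the one compound with a value clearly inside that range.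

Compound 4 `CC1(C)CC(NC(=O)Nc2ccc(Cl)cc2)c2cc(Cl)ccc2O1` is not yet measured in this assay. It differs from compound 2 in one place: 4-chlorophenyl in place of isopropyl on an amide-type nitrogen. Compound 3 shows that an aryl group on that nitrogen can go with a measurable value, 11000 nM. Compound 2, carrying the isopropyl group, is by contrast reported only as a limit. Going by the values given here, no measured pair with exactly this change exists, so the step is an expectation only. For compound 4 a step toward stronger inhibition is expected, an at least 5.0-fold lower number from compound 2 to compound 4 (0.69 log units; beyond the scatter), large enough to bring the compound inside the range of the assay. The estimate for compound 4 in this assay is 20000 nM, with a range from 6000 nM to 70000 nM.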

Compound 4, half-maximal inhibitory concentration: 33000 nM
Compound 4: middle estimate off by 1.7-fold (0.22 log units), on the low side; the measured number falls inside the stated range.
By their numbers in this assay, from the lowest: compound 3; then compound 4; then compound 1. At a limit, above all of these: compound 2.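

In this assay, going by these compounds alone, 4-chlorophenyl in place of isopropyl on the amide-type nitrogen gives an at least 3.0-fold lower number from compound 2 to compound 4 (0.48 log units; beyond the scatter), the first step between two compounds that differ in one place. This position therefore responds to the change, which takes the read-out from a limit to a measured number inside the tested range. The size of the step remains a bound and not an exact difference, as compound 2 is reported only as a limit: the limit of > 100000 nM in this assay, at which 1 of the 4 values shown sits.

Still open, on these data alone, is whether the step belongs to the aromatic ring or to its chlorine; a plain phenyl or a cyclohexyl group on the same nitrogen would separate the two. Also open, as far as these compounds go, is whether an aryl ring carrying an amine or a carboxylic acid would continue the same direction at this position.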